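Methoxy for Chloro on the Aryl Ring: Expected Inhibition

The compounds below may be only part of what the source reports. "The series", "measured", "known", "first", "only" and "open" are said of these compounds alone.

Compound 2 `Nc1ccccc1NC(=O)c1ccc(CSC(=S)N2CCN(c3ccc(Cl)cc3)CC2)cc1` stands highest of the two compounds measured in a functional assay on HeLa cells (Homo sapiens) for antiproliferative activity, read by CCK-8 assay, with a stated time of 72 h, tested at 2 uM (a higher number here means a stronger effect of the compound at the concentration tested, a lower number a weaker effect), giving 51.2%. Compound 1 `Nc1ccccc1NC(=O)c1ccc(CSC(=S)N2CCN(Cc3ccccn3)CC2)cc1` gives 14.2% in this assay. Among the compounds with values here, the one step measured so far, a number 37 percentage points higher from compound 1 to compound 2 (beyond the scatter), shows that the group on the amine nitrogen in the ring carries much of the effect. Compound 3 `COc1ccc(N2CCN(C(=S)SCc3ccc(C(=O)Nc4ccccc4N)cc3)CC2)cc1` differs from compound 2 by methoxy in place of chloro on an aromatic carbon. Within the data shown here, no measured step concerns a change of this kind; the step from compound 1 to compound 2 exchanges the whole group, not a single substituent on the aromatic ring, so it bears on the present change only loosely. Compound 3 is therefore expected to stay close to compound 2, with at most a modest shift, a number 6.2 percentage points lower from compound 2 to compound 3 (within the scatter). For compound 3 the estimate in this assay is 45%, within a range of 25% to 65%.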

Compound 3, a percentage reported as inhibition, at one concentration (the size of the read-out at that concentration, not a potency): 39.4%
Compound 3: middle estimate off by 5.6 percentage points, on the high side; measured number inside the range.
By their numbers in this assay, from the lowest: compound 1; then compound 3; then compound 2.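

In this assay, the substituent on the aromatic ring, para to a large group, proves to matter by itself: methoxy in place of chloro gives a number 11.8 percentage points lower from compound 2 to compound 3 (beyond the scatter), a smaller change than exchanging the whole group. The gain over the (pyridin-2-yl)methyl group does not depend on chloro alone, as 4-methoxyphenyl still gives a number 25.2 percentage points higher from compound 1 to compound 3 (beyond the scatter), although only two substituents on the aryl ring can be compared here. No measurement at hand accounts for the difference between chloro and methoxy.

The compounds shown leave open how an amine, a fluoro, a trifluoromethyl or an unsubstituted phenyl ring would compare with chloro and methoxy. They also leave open whether a longer chain in place of methoxy would continue the same trend.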